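This account rests on a few compounds, and the source may have more. Where it says the series, first, only, none or still open, it means among the compounds named here.

Measured compounds:
- compound 1 `CC(C)C(=O)Nc1ccc(S(=O)(=O)Oc2ccccc2I)cc1`, 13000 nM
- compound 2 `O=C(CCl)Nc1ccc(S(=O)(=O)Oc2ccccc2I)cc1`, 3900 nM

In a functional assay on M21 cells (Homo sapiens) for antiproliferative activity, read by sulforhodamine B assay, with a stated time of 48 h (on this read-out lower numbers stand for stronger inhibition and higher numbers for weaker inhibition), compound 2 stands lowest of the two numbers. Among the compounds with values here, the only measured step, a 3.3-fold lower number from compound 1 to compound 2 (0.52 log units; beyond the scatter), touches the same acyl group and shows that changes there move the number beyond the scatter.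

Compound 3 `O=C(CCCl)Nc1ccc(S(=O)(=O)Oc2ccccc2I)cc1` differs from compound 2 by chloromethyl in place of chloro on a saturated chain carbon bound to a carbonyl carbon. Within the data shown here, no measured step covers this exact change; the one measured step only shows the acyl group is sensitive, so a modest move back toward compound 1 is expected, a 2.1-fold higher number from compound 2 to compound 3 (0.31 log units; beyond the scatter). Compound 3 is therefore estimated at 8000 nM, with a range from 2500 nM to 25000 nM.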

Compound 3, half-maximal inhibitory concentration: 12000 nM
Compound 3: middle estimate off by 1.5-fold (0.18 log units), on the low side, and the stated range covers the measured number.
By their numbers in this assay, from the lowest: compound 2; then compounds 3 and 1 (each within the scatter of the next).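

In this assay, the step of a 3.1-fold higher number from compound 2 to compound 3 (0.49 log units; beyond the scatter) shows that chloromethyl in place of chloro on this saturated chain carbon gives up the gain of compound 2. With a 1.1-fold lower number from compound 1 to compound 3 (0.03 log units; within the scatter) within the scatter, 2-chloroethyl and isopropyl on the carbonyl carbon cannot be told apart, so among these three compounds the lower number goes with (chloromethyl)carbonyl alone, and a chlorine in the acyl group is not enough for it. Nothing at hand explains this difference. Open, going by these compounds, is whether bromomethyl or plain methyl on the carbonyl carbon would keep the number of compound 2, and how a longer chain such as 3-chloropropyl would read.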